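A few compounds are considered here, and "the series" means these few. Any claim that something is new, unique, unknown or untested is made for them only; others in the source may bear on it.

In a functional assay on the whole organism with Mus musculus as the target, in the maximal electroshock model (a higher number here means that more compound is needed for the effect, a lower number that less compound is needed), compound 1 `CCC1(C)CCOC1=O` gives > 500 mg/kg, which is a limit of the assay and not a number. Compound 2 `CC(C)C1(C)CCOC1=O` gives > 500 mg/kg, which is likewise a limit and not a number. Among the measured compounds shown here, compound 2 therefore has no measured dose of its own, and the series so far consists of the limit of > 500 mg/kg in this assay, at which 2 of the 2 values shown sit.

The next structure is compound 3 `CC(C)C1(C(C)C)CCOC1=O`, reached through isopropyl in place of methyl on a saturated ring carbon. For the measured compounds named here, the only measured step that bears on this change is a step that the two limits leave unreadable from compound 1 to compound 2. It concerns a neighbouring change on the same substituent type, but it offers no size to carry forward and no direction. The expectation for this assay can therefore rest only on compound 2 at > 500 mg/kg, a limit, and no large move is assumed from it. The expected change is a number no higher from compound 2 to compound 3 (the limit leaves the size open), an estimate whose direction the data do not settle. For compound 3 the estimated value is 500 mg/kg, with an expected range from 200 mg/kg to 1000 mg/kg.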

Compound 3, dose for half-maximal effect: 137 mg/kg
Beside the measured number, compound 3's estimate is 3.6-fold (0.56 log units) above it, outside the stated range (below it).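

In this assay, among the compounds shown here, isopropyl in place of methyl on a saturated ring carbon gives an at least 3.6-fold lower number from compound 2 to compound 3 (0.56 log units; beyond the scatter) and this is the first step with a readable direction. It shows that the dose responds to what is carried on the ring carbon two ring bonds from the ring oxygen, which the earlier pair could not show, as the step from compound 1 to compound 2 cannot be read. The full size of the new step remains open, because compound 2 sits at a limit and not at a number: the limit of > 500 mg/kg in this assay, at which 2 of the 3 values shown sit.

The compounds shown leave open whether the lower number belongs to isopropyl as such or would also come with a longer chain, a cyclopropyl group or a phenyl group on the same ring carbon. They also leave open how a polar group such as an amine or a carboxylic acid at this place would read in this assay, and whether the trend continues beyond isopropyl or reverses with further added carbon.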